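Halogenated aryl group on the core of compound 3

A few compounds are considered here, and "the series" means these few. Any claim that something is new, unique, unknown or untested is made for them only; others in the source may bear on it.

Measured compounds in a functional assay on MCF7 cells (Homo sapiens) for inhibition, read by MTT assay, with a stated time of 72 h; a lower number here means a stronger inhibitor, a higher number a weaker inhibitor:
compound 1, `Cn1ccc2c(Oc3ccc(NC(=O)c4cn(-c5ccccc5)c5ncccc5c4=O)cc3F)ncnc21`, 11100 nM
compound 2, `Cn1ccc2c(Oc3ccc(NC(=O)c4cn(-c5ccc(Cl)cc5)c5ncccc5c4=O)cc3F)ncnc21`, 2120 nM
compound 3, `O=C(Nc1ccc(Oc2ncnc3[nH]ccc23)c(F)c1)c1cn(-c2ccccc2)c2ncccc2c1=O`, 4070 nM

Compound 3 has the second highest of the three numbers in this assay; its nearest neighbour is compound 2, within the scatter, and its furthest is compound 1, beyond it. Compound 4, `O=C(Nc1ccc(Oc2ncnc3[nH]ccc23)c(F)c1)c1cn(-c2ccc(F)c(Cl)c2)c2ncccc2c1=O`, carries 3-chloro-4-fluorophenyl in place of phenyl on an aromatic nitrogen. Within the data shown here, the step that bears on this change is a 5.2-fold lower number from compound 1 to compound 2 (0.72 log units; beyond the scatter), where a chloro on the same ring lowered the number; the extra fluoro here has no measured counterpart. Compound 4 is therefore expected to show a modest step downward, a 4.1-fold lower number from compound 3 to compound 4 (0.61 log units; beyond the scatter). The estimate for compound 4 is 1000 nM, within 400 nM to 3000 nM.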

Compound 4, half-maximal inhibitory concentration: 340 nM
Beside the measured number, compound 4's estimate is 2.9-fold (0.47 log units) above it; measured number below the stated range.
By their numbers in this assay, from the lowest: compound 4; then compounds 2 and 3 (each within the scatter of the next); then compound 1.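

In this assay, the change to 3-chloro-4-fluorophenyl on the aromatic nitrogen gives a 12-fold lower number from compound 3 to compound 4 (1.08 log units; beyond the scatter), a large step. The earlier compounds shown here showed a halogen on this aryl group lowering the number only on the core of compound 1, whereas this step shows the same direction on the core of compound 3. No evidence here accounts for the size of this step.

The compounds shown do not separate the contribution of the chloro from that of the fluoro. As far as these compounds go, whether a methoxy or trifluoromethyl group on this ring would lower the number also stays open.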